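Swapping hydroxymethyl for carboxy on compound 2

A few compounds are considered here, and "the series" means these few. Any claim that something is new, unique, unknown or untested is made for them only; others in the source may bear on it.

Compound 1 `CCC(CC)(c1ccc(OCC(O)C(C)(C)C)c(C)c1)c1ccc(C(=O)NCCCO)n1C`: 16400 nM
Compound 2 `CCn1c(C(=O)N[C@@H](C)CO)ccc1C(CC)(CC)c1ccc(OCC(O)C(C)(C)C)c(C)c1`: 307 nM
Compound 3 `CCC(CC)(c1ccc(OCC(=O)C(C)(C)C)c(C)c1)c1ccc(C(=O)N[C@@H](CC(=O)O)C(=O)O)n1C`: 160 nM

All three values come from a functional assay on MCF7 cells (Homo sapiens) for cytotoxicity, read by MTT assay, with a stated time of 48 h; a lower number here means a stronger inhibitor, a higher number a weaker inhibitor. Compound 2 (307 nM) and compound 3 (160 nM) lie within the usual scatter of each other. Compound 1 (16400 nM) has a much higher number, well beyond the scatter from compound 2, and so is the weaker inhibitor of that pair.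

Compound 4 `CCn1c(C(=O)N[C@@H](C)C(=O)O)ccc1C(CC)(CC)c1ccc(OCC(O)C(C)(C)C)c(C)c1` has not yet been measured. It differs from compound 2 in one place: carboxy in place of hydroxymethyl on a saturated chain carbon bound to an amide-type nitrogen and a saturated chain carbon.

Among the measured compounds shown here, no measured pair shows this exchange on its own, so the evidence is indirect. Compound 3 also carries carboxy and gives a low number (160 nM), which suggests that carboxy need not bring a large loss. However, compound 3 differs from compound 2 in other places too, so it is only a loose guide. Compound 1 (16400 nM) shows that close relatives can lie far higher, which leaves the range wide on its upper side.

No change beyond the scatter is expected, and the estimate is a 1.6-fold higher number from compound 2 to compound 4 (0.21 log units; within the scatter) (a slightly weaker result at most likely). For compound 4 the estimated value is 500 nM (expected range 100 nM to 3000 nM).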

Compound 4, half-maximal inhibitory concentration: 180 nM
The estimate for compound 4 lay 2.8-fold (0.44 log units) above the measured number; low and high end bracket the measured number.
By their numbers in this assay, from the lowest: compounds 3, 4 and 2 (each within the scatter of the next); then compound 1.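

In this assay, replacing hydroxymethyl with carboxy gives a 1.7-fold lower number from compound 2 to compound 4 (0.23 log units; within the scatter), so at this position the two groups cannot be told apart in this test. Among the compounds shown here, until now, carboxy had been seen only in compound 3, which differs from compound 2 in other places too, so its effect could not be separated from theirs; compound 2 and compound 4 differ in this one place, and they show that the exchange on its own, with one more heavy atom and a new double bond, brings no loss beyond the scatter. Nothing measured here bears on why the two groups read alike.

The compounds shown cover only these two groups at this position, so it remains open whether the tolerance extends to other groups, such as an amine, a methyl ester or a primary amide. Going by these compounds, it is also open whether carboxy would read the same on a longer chain, or with the opposite arrangement at the saturated chain carbon that carries it.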